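Trifluoromethyl in place of 4-chlorophenyl: notes on compound 3

This account rests on a few compounds, and the source may have more. Where it says the series, first, only, none or still open, it means among the compounds named here.

In a functional assay on Hs-578T cells (Homo sapiens) for inhibition, read by sulforhodamine B assay, with a stated time of 48 h, tested at 10 uM (a lower number here means less inhibition of growth, a higher number more inhibition of growth at the concentration tested), compound 1 (`CC(=O)c1ccc(NC(=O)Cn2nc(-c3ccc(Cl)cc3)nc2N)cc1`) gives 6.29% and compound 2 (`C/C(=N\O)c1ccc(NC(=O)Cn2nc(-c3ccc(Cl)cc3)nc2N)cc1`) gives 11.2% so the two lie within the scatter of each other. Compound 3 (`CC(=O)c1ccc(NC(=O)Cn2nc(C(F)(F)F)nc2N)cc1`) carries trifluoromethyl in place of 4-chlorophenyl on an aromatic carbon, and the difference from compound 1 counts as trifluoromethyl in place of 4-chlorophenyl on an aromatic carbon with the rest of the core unchanged. Going by the values given here, the one measured step of a number 4.9 percentage points higher from compound 1 to compound 2 (within the scatter) leaves the 4-chlorophenyl in place, so no measurement yet shows what replacing that group does. The expectation therefore starts from compound 1 at 6.29% and assigns no direction. In this assay the expected step is a number 0.3 percentage points lower from compound 1 to compound 3 (within the scatter) and it is estimated to stay within the scatter. For compound 3 the estimated value is 6% with an expected range from -3% to 17% for repeated measurements.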

Compound 3, percent growth inhibition at one concentration: 7.42%
Estimate against measurement, compound 3: 1.4 percentage points below, within the range that was stated.
By their numbers in this assay, from the lowest: compounds 1, 3 and 2 (each within the scatter of the next).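

In this assay, going by these compounds alone, the step of a number 1.1 percentage points higher from compound 1 to compound 3 (within the scatter) is the first measured change at this aromatic carbon between two ring nitrogen atoms, and the two values cannot be told apart. Here trifluoromethyl, with no ring, stands in place of 4-chlorophenyl, with one six-membered aromatic ring, so this comparison shows no need for that ring to reach the reading of compound 1. Nothing measured here speaks to why the two compounds read alike.

Open, from the compounds shown here alone, is whether an amine, a carboxylic acid or a longer alkyl chain at this carbon would read apart from compound 1 in this assay. Also open, going by these compounds, is whether trifluoromethyl gives a similar reading on the core of compound 2.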